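From 2-chlorophenyl to 4-fluorophenyl in the series

This account rests on a few compounds, and the source may have more. Where it says the series, first, only, none or still open, it means among the compounds named here.

In a functional assay on HCT-116 cells (Homo sapiens) for antiproliferative activity, read by MTT assay, with a stated time of 72 h (on this read-out lower numbers stand for stronger inhibition and higher numbers for weaker inhibition), compound 1 `NC1=NC2(CCOCC2)N(OCCCOc2ccc(Cl)cc2)C(N)=N1` gives 690 nM and compound 2 `NC1=NC2(CCOCC2)N(OCCCOc2ccccc2Cl)C(N)=N1` gives 70 nM on the shared core. Within the data shown here, compound 2 therefore holds the lower of only two numbers, and the gap between them lies beyond the scatter.

Compound 3 `NC1=NC2(CCOCC2)N(OCCCOc2ccc(F)cc2)C(N)=N1` is not yet measured. It has 4-fluorophenyl in place of the 2-chlorophenyl of compound 2 on an oxygen on a saturated carbon (4-fluorophenyl in place of 2-chlorophenyl on an oxygen on a saturated carbon).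

Among the measured compounds shown here, one measured step bears on this change: a 9.9-fold lower number from compound 1 to compound 2 (0.99 log units; beyond the scatter) with 2-chlorophenyl in place of 4-chlorophenyl, a modest step. Compound 3 gives up the 2-chlorophenyl, so much of that step is expected to be lost, and a higher number than for compound 2 is expected in this assay overall. No measured pair compares fluorine with chlorine, and the range is kept wide for that reason. The expected size of the change is a 5.7-fold higher number from compound 2 to compound 3 (0.76 log units; beyond the scatter) in this series. For compound 3 the estimated value is 400 nM with an expected range of 120 nM to 1300 nM in this read-out.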

Compound 3, half-maximal inhibitory concentration: 3280 nM
The estimate for compound 3 lay 8.2-fold (0.91 log units) below the measured number, outside the stated range (above it).
By their numbers in this assay, from the lowest: compound 2; then compound 1; then compound 3.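

In this assay, replacing 2-chlorophenyl with 4-fluorophenyl is a large step, a 47-fold higher number from compound 2 to compound 3 (1.67 log units; beyond the scatter), which shows that this position on the oxygen-linked chain tolerates the change poorly and that the series can move further than the modest step seen earlier, a 9.9-fold lower number from compound 1 to compound 2 (0.99 log units; beyond the scatter). With the ring position held, fluoro in place of chloro on an aromatic carbon gives a 4.8-fold higher number from compound 1 to compound 3 (0.68 log units; beyond the scatter), so the identity of the halogen matters as well as its placement, and both changes raise the number among these three compounds. No measurement given here accounts for either difference.

The compounds shown leave open whether 2-fluorophenyl would retain the low number of compound 2 at 70 nM, which would separate the contribution of the halogen's placement from that of its identity. Going by these compounds, it also remains open whether the low number depends on a halogen at all, a question that unsubstituted phenyl or 2-methoxyphenyl in the same place could address.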